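Heteroaryl thioether exchange on the urea series

The source may report more compounds than this note shows. Statements on the series, on what has been measured and on what is new or still open speak of the compounds shown alone.

The shared core is a urea; compound 1 `CCCCCCN(CCCCCSc1nc2ccc[nH]c-2n1)C(=O)Nc1ccc(F)cc1F` and compound 2 `CCCCCCCN(CCCCCSc1nc(O)c2ccccc2n1)C(=O)Nc1ccc(F)cc1F` differ in the chain on the urea nitrogen and in the heteroaryl group on the sulfur. In an assay on microsomes from liver for inhibition of sterol O-acyltransferase 1 (Rattus norvegicus) (a higher number here means a weaker inhibitor, a lower number a stronger inhibitor), compound 1 gives 3600 nM, and compound 2 gives 4000 nM, the higher of the two numbers, though the gap to compound 1 lies within the scatter, so no order between them is claimed. Compound 3 `CCCCCCCN(CCCCCSc1nc(N)c2c[nH]nc2n1)C(=O)Nc1ccc(F)cc1F` is the next member. Its change from compound 2 is a group of 10 heavy atoms (5 carbon, 5 nitrogen; one five-membered aromatic ring with 2 hetero atoms, one six-membered aromatic ring with 2 hetero atoms) in place of a group of 11 heavy atoms (8 carbon, 2 nitrogen, 1 oxygen; one six-membered aromatic ring of carbon only, one six-membered aromatic ring with 2 hetero atoms), on a sulfur. Among the measured compounds shown here, no step between measured compounds isolates an exchange of this kind, so nothing anchors a direction; both measured heteroaryl groups sit at a similar level in this assay. The expected step from compound 2 to compound 3 in this assay is therefore no change at the digits printed from compound 2 to compound 3 (within the scatter), that is, none beyond the scatter. Compound 3 is estimated at 4000 nM in this assay, with a range from 1300 nM to 12000 nM.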

Compound 3, half-maximal inhibitory concentration: 4230 nM
Compound 3: the middle estimate sits 1.1-fold (0.02 log units) below what was measured; the range from low to high includes it.
By their numbers in this assay, from the lowest: compounds 1, 2 and 3 (each within the scatter of the next).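

Replacing 4-hydroxyquinazolin-2-yl on the sulfur with the group built from a five-membered aromatic ring with 2 hetero atoms and a six-membered aromatic ring with 2 hetero atoms gives a 1.1-fold higher number from compound 2 to compound 3 (0.02 log units; within the scatter) in this assay, with the rest of the molecule unchanged. This assay therefore does not separate these two groups at this place, even though the entering group has 2 hydrogen-bond donors and 4 hydrogen-bond acceptors where the leaving group has 1 and 3. No supporting measurement bears on this result.

On these data alone, whether the same level holds for a plain phenyl, a carboxylic acid or a simple amine on the sulfur remains open. As far as these compounds go, compound 1 differs from compound 2 in two places, so the effect of the chain on the urea nitrogen cannot be read apart, and a longer chain there also remains untested in these data.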